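The source may hold more compounds than are shown below. What is called first, only, known or untested is meant among the compounds shown, and "the series" means these compounds.

Measured so far:
compound 1, `N#CC1CN1C(=O)Nc1ccccc1`, 2600 nM in a functional assay on MCF7 cells (Homo sapiens) for inhibition; on this read-out higher numbers stand for weaker inhibition and lower numbers for stronger inhibition
compound 2, `N#CC1CN1C(=O)Nc1ccc(C(F)(F)F)cc1`, 1400 nM in this assay

Among the compounds with values here, compound 1 and compound 2 are the only two compounds measured, and their values lie within the scatter of each other, as a 1.9-fold lower number from compound 1 to compound 2 (0.27 log units; within the scatter) shows. Compound 3, `CC(=O)c1cccc(NC(=O)N2CC2C#N)c1`, has not yet been measured in this assay. It differs from compound 1 by acetyl in place of hydrogen on an aromatic carbon. Within the data shown here, the only measured step that bears on a substituent entering the aromatic ring of compound 1 is the one from compound 1 to compound 2, which was a 1.9-fold lower number from compound 1 to compound 2 (0.27 log units; within the scatter); that step stayed within the scatter, and nothing else measured here speaks to an acetyl group or to this place on the ring. The expectation for compound 3 is therefore no step beyond the scatter, with a 1.3-fold lower number from compound 1 to compound 3 (0.11 log units; within the scatter) as the estimated change in this assay. Compound 3 is estimated at 2000 nM, within a range of 700 nM to 6000 nM.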

Compound 3, half-maximal inhibitory concentration: 3200 nM
Compound 3: middle estimate off by 1.6-fold (0.20 log units), on the low side; measured number inside the range.
By their numbers in this assay, from the lowest: compounds 2, 1 and 3 (each within the scatter of the next, the first and the last beyond it).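

In this assay, acetyl on an aromatic carbon, meta to a group of 8 heavy atoms, gave a 1.2-fold higher number from compound 1 to compound 3 (0.09 log units; within the scatter), so this position accepted a group of 3 heavy atoms, with a double bond and a hydrogen-bond acceptor, without a step beyond the scatter. This is the second substituent on the aromatic ring of compound 1 to stay within the scatter, after the trifluoromethyl step, a 1.9-fold lower number from compound 1 to compound 2 (0.27 log units; within the scatter), and neither compound shown separates itself from compound 1. Nothing available here accounts for the size of the acetyl step.

Going by these compounds, whether an amine, a carboxylic acid or a longer chain at this place would move the number beyond the scatter remains open. So does whether acetyl elsewhere on the ring would give the same result.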